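The compounds below may be only part of what the source reports. "The series", "measured", "known", "first", "only" and "open" are said of these compounds alone.

Measured compounds:
- compound 1, `COc1ccc(OC)c(/C=C/c2nnc(Nc3ccc(Cl)cc3)o2)c1` 
- compound 2, `COc1ccc(OC)c(/C=C/C(=O)N/N=C/c2ccc(Cl)cc2)c1` 

Compound 1 reaches only the limit of a functional assay on NCI/ADR-RES cells (Homo sapiens) for antiproliferative activity, read by sulforhodamine B assay, with a stated time of 48 h; a lower number here means that less compound is tolerated, a higher number that more compound is tolerated: in this assay compound 1 gives > 100000 nM, a limit rather than a number, (the limit of > 100000 nM in this assay, at which 1 of the 2 values shown sits). Among the compounds with values here, compound 2 is the one compound with a numeric value; in this assay compound 2 gives 90600 nM. Compound 3, `COc1ccc(OC)c(/C=C/C(=O)N/N=C/c2ccccc2)c1`, differs from compound 2 by hydrogen in place of chloro on an aromatic carbon. Within the data shown here, no step of this kind is measured here, so the expected step of a 1.2-fold higher number from compound 2 to compound 3 (0.08 log units; within the scatter) is small and not beyond the scatter, if anything toward more tolerated. Compound 3 is thus estimated at 110000 nM, in the range 40000 nM to 300000 nM, with a fair chance that only a limit is reported.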

Compound 3, concentration lethal to 50% of the cells: > 100000 nM
Compound 3 ended at the assay's limit (the forecaster's own chance of this, stated with the estimate: 55%); the middle value lies beyond the limit too.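

Within the data shown here, for the first time the chloro at this position is tested directly: in this assay, replacing 4-chlorophenyl with phenyl gives an at least 1.1-fold higher number from compound 2 to compound 3 (0.04 log units; that floor lies within the scatter). Because compound 3 reaches only a limit, this step has a floor but no measured size, so it does not show that the chloro matters or that it does not. The comparison has little room to resolve a difference: the limit of > 100000 nM in this assay, at which 2 of the 3 values shown sit.

As far as these compounds go, it remains open how far the true step extends beyond that floor. From the compounds shown here alone, it is also open whether a methoxy group, an amine or a carboxylic acid at this position would give a value clearly separate from the limit.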